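The compounds below may be only part of what the source reports. "The series", "measured", "known", "first", "only" and "open" are said of these compounds alone.

Of the compounds shown here, three built on one shared core have been tested in an assay for inhibition of Tryptophan 2,3-dioxygenase (Homo sapiens), with stated times of 10 min and 60 min; on this read-out lower numbers stand for stronger inhibition and higher numbers for weaker inhibition. Compound 1 `Nc1cccc(CNc2cc(C(F)(F)F)cc3[nH]ncc23)c1` gives 2510 nM. Compound 2 `Oc1ccc(CNc2cc(C(F)(F)F)cc3[nH]ncc23)cc1` gives 2550 nM, and the step of a 1.0-fold higher number from compound 1 to compound 2 (0.01 log units; within the scatter) shows that swapping one aromatic ring for another changed nothing of note. Compound 3 `FC(F)(F)c1cc(NC[C@H]2CCCCN2)c2cn[nH]c2c1` gives 460 nM, the lowest of the three numbers; the steps of a 5.5-fold lower number from compound 1 to compound 3 (0.74 log units; beyond the scatter) and a 5.5-fold lower number from compound 2 to compound 3 (0.74 log units; beyond the scatter) both lie beyond the scatter, so compound 3 is the strongest inhibitor measured so far.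

Compound 4 `FC(F)(F)c1cc(NC[C@H]2CCCN2)c2cn[nH]c2c1` has not yet been measured. It differs from compound 3 in one place: pyrrolidin-2-yl in place of piperidin-2-yl on a saturated chain carbon bound to a nitrogen on an aromatic ring. The saturated ring with its nitrogen is kept; only the ring size changes.

Going by the values given here, the only measured steps that touch this part of the molecule are a 5.5-fold lower number from compound 1 to compound 3 (0.74 log units; beyond the scatter) and a 5.5-fold lower number from compound 2 to compound 3 (0.74 log units; beyond the scatter), which replace an aromatic ring with piperidin-2-yl. Among the compounds with values here, no measured pair compares two saturated rings of different size, so nothing here speaks directly to the change. What the data do show is that the saturated nitrogen ring is tied to the low number of compound 3, and compound 4 keeps such a ring. The step to compound 4 in this assay is therefore expected to be small, a 1.5-fold higher number from compound 3 to compound 4 (0.18 log units; within the scatter), within or near the scatter. Compound 4 is expected to give about 700 nM, with a range from 250 nM to 2000 nM.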

Compound 4, half-maximal inhibitory concentration: 6090 nM
The estimate for compound 4 lay 8.7-fold (0.94 log units) below the measured number; measured number outside the range, above it.
By their numbers in this assay, from the lowest: compound 3; then compounds 1 and 2 (each within the scatter of the next); then compound 4.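

In this assay, ring size at this position turns out to matter a great deal: going from the six-membered piperidin-2-yl to the five-membered pyrrolidin-2-yl gives a 13-fold higher number from compound 3 to compound 4 (1.12 log units; beyond the scatter), a large loss of inhibition. A saturated ring with a nitrogen is therefore not enough in itself, since compound 4 also ends up weaker than both aromatic compounds, with a 2.4-fold higher number from compound 1 to compound 4 (0.38 log units; beyond the scatter) and a 2.4-fold higher number from compound 2 to compound 4 (0.38 log units; beyond the scatter). The advantage over the aromatic rings belongs to piperidin-2-yl in compound 3 rather than to saturated nitrogen rings in general, and no measured evidence is available to explain why the ring size counts for so much.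

The compounds shown leave open whether a still larger ring, such as azepan-2-yl, would lower the number further or raise it, and whether the ring nitrogen is needed at all, which a cyclohexyl group in place of piperidin-2-yl would test. The opposite mirror-image form of the piperidin-2-yl group also remains an open question, so the role of the defined stereocentre at this position cannot yet be judged.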